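Naphthyl in place of methoxyphenyl on the pyrazoline carbon

This account rests on a few compounds, and the source may have more. Where it says the series, first, only, none or still open, it means among the compounds named here.

Measured so far:
Compound 1 `COc1ccc(C2CC(c3ccccc3)=NN2C2=NC(=O)/C(=C3\C(=O)Nc4ccccc43)S2)cc1` — 1640 nM
Compound 2 `COc1ccc(C2=NN(C3=NC(=O)/C(=C4\C(=O)Nc5ccccc54)S3)C(c3ccc(OC)cc3)C2)cc1` — 100000 nM

Of the compounds shown here, two sharing one core have been tested in a functional assay on cells (Leukemia cell, Homo sapiens) for cytotoxicity, read by sulforhodamine B assay, with a stated time of 48 h; a higher number here means a weaker inhibitor of growth, a lower number a stronger inhibitor of growth. Compound 1 `COc1ccc(C2CC(c3ccccc3)=NN2C2=NC(=O)/C(=C3\C(=O)Nc4ccccc43)S2)cc1` gives 1640 nM. Among the compounds with values here, compound 2 `COc1ccc(C2=NN(C3=NC(=O)/C(=C4\C(=O)Nc5ccccc54)S3)C(c3ccc(OC)cc3)C2)cc1` gives 100000 nM, the higher of the two numbers, and its only neighbour is compound 1, reached by a 61-fold higher number from compound 1 to compound 2 (1.79 log units; beyond the scatter).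

Compound 3 `COc1ccc(C2CC(c3ccc4ccccc4c3)=NN2C2=NC(=O)/C(=C3\C(=O)Nc4ccccc43)S2)cc1` has not yet been measured. It differs from compound 2 in one place: naphthalen-2-yl in place of 4-methoxyphenyl on a carbon with a double bond to nitrogen. Within the data shown here, the one measured step bears directly on this change, since it shows what the methoxy group does on this aromatic ring: a 61-fold higher number from compound 1 to compound 2 (1.79 log units; beyond the scatter), a large move. Compound 3 removes that methoxy and, at the same position, fuses a second aromatic ring to the first. The data contain no step for such a fused ring, so its own effect cannot be read from the numbers shown.

The expected step for compound 3 is therefore a return toward the level of compound 1, tempered by the unknown contribution of the second ring: a 25-fold lower number from compound 2 to compound 3 (1.40 log units; beyond the scatter). Compound 3 is estimated at 4000 nM, with a range from 900 nM to 40000 nM.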

Compound 3, concentration for 50% growth inhibition: 17500 nM
Compound 3: middle estimate off by 4.4-fold (0.64 log units), on the low side, within the range that was stated.
By their numbers in this assay, from the lowest: compound 1; then compound 3; then compound 2.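

In this assay, naphthalen-2-yl in place of 4-methoxyphenyl on this carbon with a double bond to nitrogen wins back only part of the earlier loss, giving a 5.7-fold lower number from compound 2 to compound 3 (0.76 log units; beyond the scatter), while the same group in place of phenyl still gives an 11-fold higher number from compound 1 to compound 3 (1.03 log units; beyond the scatter). The penalty at this position is therefore not tied to the methoxy group alone: naphthalen-2-yl carries no methoxy, yet among these three compounds plain phenyl in compound 1 still gives the lowest number, and both other groups sit clearly higher, with 4-methoxyphenyl in compound 2 the highest. No measurement shown explains why the three groups fall in this order.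

The compounds shown leave open where a small group such as methyl, or a phenyl ring bearing an amine or a carboxylic acid, would fall in this order on the same carbon. They also leave open whether this order would hold if the 4-methoxyphenyl group on the other ring atom, common to all three compounds, were replaced by plain phenyl.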